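The source may report more compounds than this note shows. Statements on the series, on what has been measured and on what is new or still open speak of the compounds shown alone.

Within the data shown here, in a functional assay on MDA-MB-231 cells (Homo sapiens) for antiproliferative activity, read by MTT assay, with a stated time of 72 h (on this read-out higher numbers stand for weaker inhibition and lower numbers for stronger inhibition), only two compounds with the shared core have numbers so far. Compound 1 `CC1=CC[C@H]2[C@@H]1CC=C(C)[C@@H](CC[C@H]1[C@]3(C)CC[C@H](OC(=O)c4ccccc4)C(C)(C)O[C@H]3CC[C@@]1(C)O)C2(C)C` gives 18400 nM and compound 2 `CC1=CC[C@H]2[C@@H]1CC=C(C)[C@@H](CC[C@H]1[C@]3(C)CC[C@H](OC(=O)c4ccncc4)C(C)(C)O[C@H]3CC[C@@]1(C)O)C2(C)C` gives 19100 nM, so compound 2 stands level with compound 1. Among the measured compounds shown here, the one measured step, a 1.0-fold higher number from compound 1 to compound 2 (0.02 log units; within the scatter), comes from pyridin-4-yl in place of phenyl on a carbonyl carbon.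

Compound 3 `CC1=CC[C@H]2[C@@H]1CC=C(C)[C@@H](CC[C@H]1[C@]3(C)CC[C@H](OCc4ccccc4)C(C)(C)O[C@H]3CC[C@@]1(C)O)C2(C)C` has not yet been measured. It has benzyl in place of (pyridin-4-yl)carbonyl on an oxygen on a saturated carbon, a change counted as benzyl in place of (pyridin-4-yl)carbonyl on an oxygen on a saturated carbon. The measured step bears on this only in part. It shows that exchanging the ring on the carbonyl carbon left the number within the scatter, which makes the carbon-only ring of compound 3 a change of little expected weight. However, no measured pair loses the carbonyl itself, so the data give no direct guide to that part of the change, and the range must stay wide.

No clear shift in either direction is expected, and the estimated step is a 1.1-fold lower number from compound 2 to compound 3 (0.05 log units; within the scatter). For compound 3 the expected value is 17000 nM, with an estimated range from 7000 nM to 40000 nM.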

Compound 3, half-maximal inhibitory concentration: 35700 nM
Beside the measured number, compound 3's estimate is 2.1-fold (0.32 log units) below it; measured number inside the range.
By their numbers in this assay, from the lowest: compounds 1, 2 and 3 (each within the scatter of the next).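

In this assay, among these compounds, the oxygen on a saturated carbon carries a group without a carbonyl for the first time, and benzyl in place of (pyridin-4-yl)carbonyl gives a 1.9-fold higher number from compound 2 to compound 3 (0.27 log units; within the scatter). The pair that keeps a carbon-only ring, benzyl in place of benzoyl, isolates the loss of the carbonyl more cleanly and gives a 1.9-fold higher number from compound 1 to compound 3 (0.29 log units; within the scatter). The earlier pair had exchanged only the ring on the carbonyl carbon, whereas these steps show that the carbonyl can also go without a step beyond the scatter, although no information is available on what lies behind either step.

Going by these compounds, every group on this oxygen so far holds a six-membered aromatic ring, so it remains open what a group without such a ring would give, such as a longer chain ending in an amine or in a carboxylic acid. These three compounds also differ in this one place only, leaving open whether any change elsewhere on the shared core would give a step beyond the scatter.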